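A Smaller Amide Group on the Shared Core

The source may hold more compounds than are shown below. What is called first, only, known or untested is meant among the compounds shown, and "the series" means these compounds.

Among the measured compounds shown here, compound 1 `N#C[C@@H]1CCCN1C(=O)[C@@H]1C[C@H](C(=O)N2CCOCC2)CN1` is the only compound here with a measured number. In an assay on the whole organism (plasma, strain Sprague-Dawley) for inhibition of Dipeptidyl peptidase 4 (Rattus norvegicus), with a stated time of 10 h, at a dose of 1 mg/kg by the oral route (a higher number here means more inhibition at the dose given (going by the name of the read-out), a lower number less inhibition), compound 1 gives 44%. Compound 2 `N#C[C@@H]1CCCN1C(=O)[C@@H]1C[C@H](C(=O)N2CCCCCCC2)CN1` shares the core of compound 1, but in this assay compound 2 gives "not determined" (no result reported), so compound 2 stands nowhere on the numbers shown. Compound 3 `CCCNC(=O)[C@@H]1CN[C@H](C(=O)N2CCC[C@H]2C#N)C1` differs from compound 2 in one place: a group of 4 heavy atoms (3 carbon, 1 nitrogen; no ring) in place of a group of 8 heavy atoms (7 carbon, 1 nitrogen; one eight-membered non-aromatic ring with 1 hetero atom), on a carbonyl carbon. For the measured compounds named here, no measured pair connects these two compounds, so the size of the change in this assay cannot be read from any step; the value of compound 1 is the only footing. Because compound 1 gives 44% with the same core, compound 3 is expected to land near that mark, with any shift no larger than the usual scatter in either direction. For compound 3 the estimate in this assay is 40%, within a range from 15% to 65%.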

Compound 3, a percentage reported as inhibition, in the whole organism at one dose (the size of the read-out at that dose, not a potency): 21%
Beside the measured number, compound 3's estimate is 19 percentage points above it, and the stated range covers the measured number.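

On the shared core, the group on this carbonyl carbon is not a neutral choice: propylamino in place of morpholin-4-yl gives a number 23 percentage points lower from compound 1 to compound 3 (beyond the scatter) in this assay. This read-out reports inhibition at a single dose rather than a potency, so the step shows a smaller effect at that dose and does not show how tightly either compound acts on the enzyme. Nothing available explains why the number falls with this exchange.

Among the compounds shown here, compound 2 has no reported result, so no step involving it can be read, and the eight-membered ring adds nothing to the comparison. For the compounds shown here, with only this one pair, it remains open whether the lower number goes with the open chain or with the amide hydrogen, which dimethylamino or piperidin-1-yl on the same carbonyl carbon could help separate, and whether a longer chain such as hexylamino would move the number further.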